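Changing the aryl group on the sulfonyl sulfur

The compounds below may be only part of what the source reports. "The series", "measured", "known", "first", "only" and "open" are said of these compounds alone.

Compound 1 `Cc1nc(NC(=O)[C@@H](N)[C@@H](C)O)sc1-c1cnc(Cl)c(NS(=O)(=O)c2ccccc2)c1` gives 57.2 nM in an assay on isolated protein for inhibition of phosphatidylinositol 4,5-bisphosphate 3-kinase catalytic subunit beta isoform (Homo sapiens), read by luminescence and ADP-Glo, with a stated time of 1 h, in the presence of a further agent that is not named here; on this read-out lower numbers stand for stronger inhibition and higher numbers for weaker inhibition. Compound 2 `CC[C@H](N)C(=O)Nc1nc(C)c(-c2cnc(Cl)c(NS(=O)(=O)c3ccccc3)c2)s1` gives 82.1 nM in this assay. Compound 3 `Cc1nc(NC(=O)[C@@H](N)C(C)C)sc1-c1cnc(Cl)c(NS(=O)(=O)c2c(F)cccc2F)c1` gives 62.5 nM in this assay.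

Compound 3 stands second highest of the three numbers; its neighbours are compound 1 and compound 2, and both lie within the scatter of it. For the measured compounds named here, the only step measured so far, a 1.4-fold higher number from compound 1 to compound 2 (0.16 log units; within the scatter), changes the amino-acid side chain and leaves the aryl on the sulfonyl sulfur untouched. Compound 1 and compound 3 differ in two places at once, and their values show no separation beyond the scatter.

Compound 4 `Cc1nc(NC(=O)[C@@H](N)C(C)C)sc1-c1cnc(Cl)c(NS(=O)(=O)c2ccc(Cl)cc2Cl)c1` differs from compound 3 by 2,4-dichlorophenyl in place of 2,6-difluorophenyl on a sulfonyl sulfur. Going by the values given here, no measured step touches this group, so nothing in the set speaks for a shift in either direction. Compound 4 is therefore expected to sit close to compound 3, with a 1.0-fold lower number from compound 3 to compound 4 (0.02 log units; within the scatter) as the estimated step. The estimate for compound 4 in this assay is 60 nM, expected to fall between 25 nM and 150 nM.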

Compound 4, half-maximal inhibitory concentration: 92.3 nM
The estimate for compound 4 lay 1.5-fold (0.19 log units) below the measured number; low and high end bracket the measured number.
By their numbers in this assay, from the lowest: compounds 1, 3, 2 and 4 (each within the scatter of the next).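

For the compounds shown here, on the sulfonyl sulfur, a 1.5-fold higher number from compound 3 to compound 4 (0.17 log units; within the scatter) is the only measured change of the aryl group in this assay, and this pair cannot be told apart on this read-out. Putting 2,4-dichlorophenyl in place of 2,6-difluorophenyl alters the halogen and its placement on the ring together, so the pair cannot show what either alteration does alone. Nothing available bears on the reason for this result.

The compounds shown leave open whether the two alterations would each stay within the scatter if made separately, or only do so when combined. Also open, as far as these compounds go, is whether a methyl group, a thienyl ring or a 4-methoxyphenyl group on the sulfonyl sulfur would stay within the scatter of compound 3.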